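From Carbamoyl to Cyano on a Fused Core

This account rests on a few compounds, and the source may have more. Where it says the series, first, only, none or still open, it means among the compounds named here.

Measured compounds:
compound 1: `CC1CC/C(=N\Nc2cccc(C(=O)O)c2)c2nccc(=O)n21`, > 100 umol/kg
compound 2: `CC1CC/C(=N\Nc2ccccc2)c2ncc(C(N)=O)c(=O)n21`, > 1000 umol/kg

Both compounds were tested in a functional assay on the whole organism for inhibition, with Rattus norvegicus as the target; a lower number here means that less compound is needed, a higher number that more compound is needed for the effect. For compound 1 the result is a limit of the assay, > 100 umol/kg, so no number is known. For compound 2 the result is likewise a limit of the assay, > 1000 umol/kg, and compound 2 therefore stands only at that limit (the limit of > 1000 umol/kg in this assay, at which 1 of the 2 values shown sits). Among the measured compounds shown here, the two values in this assay are thus both limits (the limit of > 100 umol/kg in this assay, at which 1 of the 2 values shown sits), and no measured step between them can be counted.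

Compound 3 is not yet measured: `CC1CC/C(=N\Nc2ccccc2)c2ncc(C#N)c(=O)n21`. It differs from compound 2 in one place: cyano in place of carbamoyl on an aromatic carbon. For the measured compounds named here, no measured step guides this change, so little shift beyond the scatter is expected. The change is estimated to amount to a step that the limit leaves unreadable from compound 2 to compound 3. Compound 3 is expected to give about 1500 umol/kg, within 300 umol/kg to 10000 umol/kg, most likely again only a limit.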

Compound 3, dose for 50% inhibition: > 1000 umol/kg
Compound 3: only a limit was reported; the forecaster's own chance of this, stated with the estimate: 80%; the middle value does not contradict the limit.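

Compound 3 gives [ > 1000 umol/kg ], a limit and not a number. Compound 2 also stands only at a limit, so no step can be read between compound 2 and compound 3. The compounds shown leave open whether cyano in place of carbamoyl changes the dose needed.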